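A few compounds are considered here, and "the series" means these few. Any claim that something is new, unique, unknown or untested is made for them only; others in the source may bear on it.

Compound 1 `COc1ccc(-c2nc3cc(/C(C)=N/NC(N)=O)ccc3n2C2CCCCC2)cc1`: "not determined" (no result reported)
Compound 2 `C/C(=N\NC(N)=S)c1ccc2c(c1)nc(-c1ccc(Cl)cc1)n2C1CCCCC1`: > 100000 nM

The only data come from an ADME assay on Vero cells (Chlorocebus sabaeus) for cytotoxicity, read by MTT assay, with a stated time of 96 h (on this read-out higher numbers stand for lower toxicity in this test and lower numbers for higher toxicity in this test), and they are thin. Compound 1 has no result there, so it offers no comparison. Compound 2 gives > 100000 nM, which is a limit of the assay and not a number. The whole record therefore comes down to this: the limit of > 100000 nM in this assay, at which 1 of the 2 values shown sits. Compound 2 has no single number to anchor a step.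

The next compound to be tested is compound 3 `COc1ccc(-c2nc3cc(/C(C)=N/NC(N)=S)ccc3n2C2CCCCC2)cc1`. It differs from compound 2 at one place: methoxy in place of chloro on an aromatic carbon. This is methoxy in place of chloro on an aromatic carbon, para to a large group, so that 4-chlorophenyl becomes 4-methoxyphenyl.

Going by the values given here, no measured pair shows what this change does in this assay, so the expectation rests on compound 2 alone. The expected step is a number no higher from compound 2 to compound 3 (the limit leaves the size open), and no shift beyond the scatter is expected in either direction. The assay may well report only a limit again. Compound 3 is estimated at 100000 nM, with an expected range from 35000 nM to 200000 nM.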

Compound 3, half-maximal cytotoxic concentration: 40000 nM
Compound 3: the middle estimate sits 2.5-fold (0.40 log units) above what was measured; the range from low to high includes it.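

With methoxy in place of chloro on an aromatic carbon, para to a large group, this assay shows an at least 2.5-fold lower number from compound 2 to compound 3 (0.39 log units; beyond the scatter), so this position can affect the read-out, with the lower number standing for higher toxicity in this test. Going by these compounds alone, compound 3 gives 40000 nM, the first single number and a firm reference point that the earlier compounds did not provide. Going by these compounds, how large the step really is stays open, because its starting point is a limit of the assay and not a number: the limit of > 100000 nM in this assay, at which 1 of the 3 values shown sits.

The compounds shown do not tell whether this shift is particular to methoxy, as a single change at a single position cannot show how a hydroxyl, an amine, a carboxylic acid or a longer alkoxy chain would behave there. Compound 3 also shares the 4-methoxyphenyl group with compound 1, but compound 1 gives "not determined" (no result reported), so the group that sets these two compounds apart cannot be assessed in this assay.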